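Cyclohexyl for Cyclopentyl on the Amide Nitrogen

A few compounds are considered here, and "the series" means these few. Any claim that something is new, unique, unknown or untested is made for them only; others in the source may bear on it.

Three measured compounds share one core and differ in the group carried on the amide-type nitrogen: compound 1 `COCCNC(=O)c1cc2cccc(OC)c2oc1=N`, compound 2 `COc1cccc2cc(C(=O)NC3CCCC3)c(=N)oc12` and compound 3 `COc1ccc(-n2cnc(C#N)c2NC(=O)c2cc3cccc(OC)c3oc2=N)cc1`. In an assay on CHO cells for displacement of a labelled ligand from adenosine receptor A1 (Homo sapiens), read by scintillation counting, with a stated time of 60 min, tested at 10 uM (on this read-out higher numbers stand for more inhibition at the one concentration tested (going by the name of the read-out) and lower numbers for less inhibition), compound 1 gives > 70%, which is a limit of the assay rather than a number. In this assay compound 2 likewise gives > 70%, again a limit. In this assay compound 3 gives 37%. The step that the two limits leave unreadable from compound 1 to compound 2 is therefore of unreadable size, and compound 2 stands only at a limit, at the mark (the limit of > 70% in this assay, at which 2 of the 3 values shown sit).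

Compound 4 `COc1cccc2cc(C(=O)NC3CCCCC3)c(=N)oc12` is reached by a single change: cyclohexyl in place of cyclopentyl on an amide-type nitrogen. Among the measured compounds shown here, no measured step speaks directly to this change; the one step that touches the same amide-type nitrogen cannot be read in size, so nothing in the data shows how far a change of ring size at this position moves the read-out. With compound 2 at a limit in this assay, the step that the limit leaves unreadable from compound 2 to compound 4 is expected to be small, within the scatter, in no fixed direction. Compound 4 is therefore estimated at 75%, with a range from 55% to 92%.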

Compound 4, a percentage reported as inhibition, at one concentration (the size of the read-out at that concentration, not a potency): 40%
Estimate against measurement, compound 4: 35 percentage points above; the whole stated range lies above it.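

Among the compounds shown here, the amide-type nitrogen turns out to respond to the size of its ring of carbon: in this assay, cyclohexyl in place of cyclopentyl gives a number at least 30 percentage points lower from compound 2 to compound 4 (beyond the scatter), the first step at this position whose size can be read at all. Cyclohexyl in place of 2-methoxyethyl on the same nitrogen gives a number at least 30 percentage points lower from compound 1 to compound 4 (beyond the scatter), so this change too leaves the read-out clearly lower and shows that not every group carried here keeps it at the limit. Both steps give only a minimum size, and the step from compound 1 to compound 2 cannot be read, because compound 1 and compound 2 are known only as a limit: the limit of > 70% in this assay, at which 2 of the 4 values shown sit.

Going by these compounds, whether the read-out keeps dropping with a cycloheptyl ring on this nitrogen, or whether a cyclobutyl ring holds it at the limit as cyclopentyl does, remains open. Also open is whether a hydroxyl group or an amine placed on the cyclohexyl ring would bring the read-out back up, so the compounds shown fix neither the shape of the ring-size trend nor what the six-membered ring can carry.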